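Replacing the carboxy group of compound 3

The compounds below may be only part of what the source reports. "The series", "measured", "known", "first", "only" and "open" are said of these compounds alone.

In a functional assay on HCT-116 cells (Homo sapiens) for inhibition, read by MTT assay, with a stated time of 72 h (a lower number here means a stronger inhibitor of growth, a higher number a weaker inhibitor of growth), compound 1 `CNC(=O)/C=C/c1ccncc1-c1ccc2ccccc2c1` gives 6550 nM as a measured result. For compound 2 `O=C(O)[C@@H]1CCCN1C(=O)/C=C/c1ccncc1-c1ccc2ccccc2c1` the entry reads "not determined" (no result reported) and so it adds nothing here. Compound 3 `O=C(O)/C=C/c1ccncc1-c1ccc2ccccc2c1` reaches only the limit > 30000 nM in this assay and gives no exact number.

Compound 4 `COC1CN(C(=O)/C=C/c2ccncc2-c2ccc3ccccc3c2)C1` has not yet been measured. Here 3-methoxyazetidin-1-yl takes the place of hydroxy on a carbonyl carbon (3-methoxyazetidin-1-yl in place of hydroxy on a carbonyl carbon) and the rest of compound 3 stays as it is.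

Going by the values given here, one measured step bears on this change. Swapping methylamino for hydroxy on that same carbonyl carbon gives an at least 4.5-fold higher number from compound 1 to compound 3 (0.66 log units; beyond the scatter) and only the minimum size of that step is known. Among the compounds with values here, compound 4 also loses the hydroxy, so its change runs in the opposite direction, although no measured compound carries 3-methoxyazetidin-1-yl. A lower number is therefore expected, with the estimated step being an at least 4.2-fold lower number from compound 3 to compound 4 (0.63 log units; beyond the scatter) and with its size resting on this single comparison. Compound 4 is expected at 7000 nM with an estimated range from 2500 nM to 22000 nM when it is tested.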

Compound 4, concentration for 50% growth inhibition: > 30000 nM
Compound 4 ended at the assay's limit; the forecaster's own chance of this, stated with the estimate: 15%; at least 4.2-fold (0.63 log units) between middle value and limit.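

Removing the hydroxy is not enough by itself on this carbonyl carbon. In this assay compound 4 gives > 30000 nM, which is a limit of the assay and not a number, so having an amide here does not in itself bring growth inhibition into the measurable range. Going by these compounds alone, replacing methylamino with 3-methoxyazetidin-1-yl gives an at least 4.5-fold higher number from compound 1 to compound 4 (0.66 log units; beyond the scatter), which leaves methylamino as the only group at this place with a measured number so far. The step between the carboxy and the (3-methoxyazetidin-1-yl)carbonyl compounds cannot be read, and how far compound 3 and compound 4 really differ stays unknown: the limit of > 30000 nM in this assay, at which 2 of the 4 values shown sit.

Still open, as far as these compounds go, is which part of the change from methylamino matters: the four-membered ring, the methoxy on it, or the loss of the amide hydrogen. A plain azetidin-1-yl would separate the ring from the methoxy, while dimethylamino or ethylamino on the same carbonyl carbon would show how narrowly the number of compound 1 depends on methylamino itself.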